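The compounds below may be only part of what the source reports. "The series", "measured", "known", "first", "only" and "open" are said of these compounds alone.

Measured so far in a functional assay on A549 cells (Homo sapiens) for antiproliferative activity, read by CCK-8 assay, with a stated time of 72 h; on this read-out lower numbers stand for stronger inhibition of growth and higher numbers for weaker inhibition of growth:
compound 1, `CCC1C(=O)N(C)c2cnc(-n3ccc4cc(C(N)=O)ccc43)nc2N1c1ccn(C)n1`, gives 39500 nM;
compound 2, `CC[C@@H]1C(=O)N(C)c2cnc(Nc3ccc(S(N)(=O)=O)cc3)nc2N1C1CCCC1`, gives 3390 nM;
compound 3, `CCC1C(=O)N(C)c2cnc(Nc3ccc(S(=O)(=O)NCCCO)cc3)nc2N1c1ccn(C)n1`, gives 48900 nM.

Among these three numbers compound 1 holds the second highest, which places it among the weaker growth inhibitors here. Its nearest neighbour is compound 3, whose number lies close enough that the two fall within the usual scatter and cannot be ordered. Compound 2 stands well apart with the lowest number of the set, a gap that lies beyond the scatter.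

Compound 4, `CCC1C(=O)N(C)c2cnc(-n3ccc4cc(C(=O)NCC(C)C)ccc43)nc2N1c1ccn(C)n1`, differs from compound 1 in one place: isobutyl in place of hydrogen on an amide-type nitrogen. Put another way, the carbamoyl group becomes an isobutylcarbamoyl group. Among the compounds with values here, no pair of measured compounds shows the effect of this kind of change, so nothing anchors a direction. Because compound 1 gives 39500 nM and compound 3 gives 48900 nM, weak inhibition is the expected starting point, and a single isobutyl on the amide-type nitrogen is not expected to move the number far. The expected step is a 1.6-fold lower number from compound 1 to compound 4 (0.20 log units; within the scatter), small and possibly within the scatter. The estimate for compound 4 is 25000 nM, expected to fall within 8000 nM to 80000 nM.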

Compound 4, concentration for 50% growth inhibition: 19200 nM
For compound 4 the middle estimate is 1.3-fold (0.11 log units) above the measured one, within the range that was stated.
By their numbers in this assay, from the lowest: compound 2; then compound 4; then compounds 1 and 3 (each within the scatter of the next).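

Turning the carbamoyl group into an isobutylcarbamoyl group brings a 2.1-fold lower number from compound 1 to compound 4 (0.31 log units; beyond the scatter) in this assay, the first step in this set where a single change can be read on its own. The step is modest, but it shows that this amide-type nitrogen can carry an isobutyl group with no loss of growth inhibition, and with a small gain here. Nothing available explains why the number moves in this direction.

As far as these compounds go, whether this gain belongs to isobutyl in particular or would come with other groups stays open: a methyl, a longer chain such as hexyl, or a chain ending in an amine or a carboxylic acid on the same nitrogen could show how far the trend runs. Within the data shown here, with only one pair, it is also unknown whether the same change would give a similar step on another core.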